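This account rests on a few compounds, and the source may have more. Where it says the series, first, only, none or still open, it means among the compounds named here.

compound 1 `O=C(CCc1nc2ccccc2c(=O)[nH]1)N/N=C/c1ccc(O)cc1`: 238000000 nM
compound 2 `COc1cc(/C=N/NC(=O)CCCc2nc3ccccc3c(=O)[nH]2)cc(OC)c1O`: 97000000 nM
compound 3 `O=C(CCCc1nc2ccccc2c(=O)[nH]1)N/N=C/c1ccc(Cl)cc1`: 353000000 nM

In a physicochemical assay, read by spectrophotometry, with a stated time of 30 min (on this read-out lower numbers stand for stronger inhibition and higher numbers for weaker inhibition), compound 1 lies within the usual scatter of compound 3 and clearly above compound 2. Compound 4 `COc1cc(/C=N/NC(=O)CCc2nc3ccccc3c(=O)[nH]2)ccc1O` keeps the chain and core of compound 1. The change is methoxy in place of hydrogen on an aromatic carbon, turning 4-hydroxyphenyl into 4-hydroxy-3-methoxyphenyl. Among the measured compounds shown here, no measured pair shows this change alone. For the measured compounds named here, compound 2, the only measured compound carrying methoxy groups, gives 97000000 nM, although its chain also differs. A small drop, probably within the scatter, is therefore expected. The expected change is a 1.6-fold lower number from compound 1 to compound 4 (0.20 log units; within the scatter). Compound 4 is estimated at 150000000 nM, with an expected range of 65000000 nM to 330000000 nM.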

Compound 4, half-maximal inhibitory concentration: 204000000 nM
Beside the measured number, compound 4's estimate is 1.4-fold (0.13 log units) below it; low and high end bracket the measured number.
By their numbers in this assay, from the lowest: compound 2; then compounds 4, 1 and 3 (each within the scatter of the next).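

Methoxy in place of hydrogen on an aromatic carbon, ortho to a hydroxy group, can now be read on its own: in this assay the step is a 1.2-fold lower number from compound 1 to compound 4 (0.07 log units; within the scatter). This position therefore takes the added methoxy with no change that stands out from the scatter. No supporting data bear on this result. From the compounds shown here alone, whether an amine or a carboxylic acid at this position would move the number stays open, and so does whether the same methoxy step would hold with a longer chain.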